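Phenyl for Propyl on the Imine Side Chain

A few compounds are considered here, and "the series" means these few. Any claim that something is new, unique, unknown or untested is made for them only; others in the source may bear on it.

Of the compounds shown here, three sharing one core have been measured in a functional assay, read by spectrophotometry, with a stated time of 3 min; a lower number here means a stronger inhibitor, a higher number a weaker inhibitor. Compound 1 `O=c1[nH]c2ccccc2cc1/C=N/O` gives 31800 nM. Compound 2 `N/N=C/c1cc2ccccc2[nH]c1=O` gives 20600 nM. Compound 3 `CCCC/N=C/c1cc2ccccc2[nH]c1=O` gives 1810000 nM, the highest of the three numbers and so the weakest inhibitor among them: a 57-fold higher number from compound 1 to compound 3 (1.76 log units; beyond the scatter) and an 88-fold higher number from compound 2 to compound 3 (1.94 log units; beyond the scatter), both beyond the scatter, whereas a 1.5-fold lower number from compound 1 to compound 2 (0.19 log units; within the scatter) stays within it.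

Compound 4 `O=c1[nH]c2ccccc2cc1/C=N/Cc1ccccc1` differs from compound 3 in one place: phenyl in place of propyl on a saturated chain carbon bound to a double-bonded nitrogen. Among the compounds with values here, no measured step matches this change. Within the data shown here, the two large steps show only that a butyl group on the double-bonded nitrogen gives a far higher number than hydroxy or amino there; they say nothing about exchanging one carbon group for another further along that chain. In this assay the expected step is therefore modest and of uncertain direction, a 1.8-fold lower number from compound 3 to compound 4 (0.26 log units; within the scatter), since compound 3 already sits at 1810000 nM. Compound 4 is estimated at 1000000 nM, with a likely range from 150000 nM to 6000000 nM.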

Compound 4, half-maximal inhibitory concentration: 368000 nM
Estimate against measurement, compound 4: 2.7-fold (0.43 log units) above; the measured number falls inside the stated range.
By their numbers in this assay, from the lowest: compounds 2 and 1 (each within the scatter of the next); then compound 4; then compound 3.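

In this assay, within the data shown here, the earlier steps compared a butyl group only with hydroxy and amino on the double-bonded nitrogen, whereas this change lies further along the chain and gives a 4.9-fold lower number from compound 3 to compound 4 (0.69 log units; beyond the scatter) as a modest step beyond the scatter. The number therefore responds to a change on the saturated chain carbon, even though neither phenyl nor propyl carries a hydrogen-bond donor or acceptor. No measurement here gives a reason for this step.

This single pair cannot separate the effect of the aromatic ring from that of the larger group, since phenyl differs from propyl in both respects. Cyclohexyl or a longer chain in the same place would address that question, while chloro or methoxy on the phenyl ring would show whether the ring tolerates further change.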